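A few compounds are considered here, and "the series" means these few. Any claim that something is new, unique, unknown or untested is made for them only; others in the source may bear on it.

Compound 3 `COc1ccc(-c2cn(C/C=C3\OC(=O)C(OCc4ccccc4)=C3OCc3ccccc3)nn2)cc1` stands at a limit of the assay rather than at a number: in a functional assay on A549 cells (Homo sapiens) for antiproliferative activity, read by MTT assay, with a stated time of 72 h (on this read-out lower numbers stand for stronger inhibition and higher numbers for weaker inhibition), compound 3 gives > 100000 nM. The two compounds that differ from it in one place sit at the same limit. Compound 1 `O=C1O/C(=C\Cn2cc(-c3cc(F)cc(F)c3)nn2)C(OCc2ccccc2)=C1OCc1ccccc1`, bearing 3,5-difluorophenyl, gives > 100000 nM in this assay, which is a limit. Compound 2 `CCCCCc1ccc(-c2cn(C/C=C3\OC(=O)C(OCc4ccccc4)=C3OCc3ccccc3)nn2)cc1`, bearing 4-pentylphenyl, gives > 100000 nM in this assay, again a limit. The steps a step that the two limits leave unreadable from compound 1 to compound 2, a step that the two limits leave unreadable from compound 1 to compound 3 and a step that the two limits leave unreadable from compound 2 to compound 3 therefore cannot be read in size, because every value sits at the limit of > 100000 nM in this assay, at which 3 of the 3 values shown sit.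

Compound 4 `COc1ccccc1-c1cn(C/C=C2\OC(=O)C(OCc3ccccc3)=C2OCc2ccccc2)nn1` differs from compound 3 only in the arrangement of the same atoms: 2-methoxyphenyl in place of 4-methoxyphenyl on an aromatic carbon. Among the measured compounds shown here, none of the measured steps can tell how large a change this will bring, since all three compounds lie beyond the range that this assay reports. The expectation for compound 4 is therefore that it too is most likely to sit at the limit, with an estimated step that the limit leaves unreadable from compound 3 to compound 4 that is not readable, and an estimated value of 200000 nM, within 60000 nM to 700000 nM.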

Compound 4, half-maximal inhibitory concentration: > 100000 nM
Compound 4: no number, only a limit; the forecaster's own chance of this, stated with the estimate: 80%; the middle value is on the limit's open side.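

Compound 4 stands at a limit, as do compound 1, compound 2 and compound 3, so none of its steps to these three can be read in size: the limit of > 100000 nM in this assay, at which 4 of the 4 values shown sit. The compounds shown leave open which change on the shared core, if any, would bring a measurable value in this assay at all.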